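This account rests on a few compounds, and the source may have more. Where it says the series, first, only, none or still open, it means among the compounds named here.

For the measured compounds named here, compound 2 `O=C(/C=C/c1ccccc1[N+](=O)[O-])NS(=O)(=O)c1ccc(F)cc1` gives 6 ug/mL in a functional assay on B16-F10 cells (Mus musculus) for antiproliferative activity, read by ELISA and MTT assay, with a stated time of 48 h (on this read-out higher numbers stand for weaker inhibition and lower numbers for stronger inhibition), the lowest of the two numbers so far, though only within the scatter of compound 1 `Cc1ccc(S(=O)(=O)NC(=O)/C=C/c2ccccc2[N+](=O)[O-])cc1`, which gives 10.3 ug/mL; the step of a 1.7-fold lower number from compound 1 to compound 2 (0.23 log units; within the scatter) stays within the scatter. Compound 3 `O=C(/C=C/c1ccccc1[N+](=O)[O-])NS(=O)(=O)c1ccc(Br)cc1` differs from compound 2 by bromo in place of fluoro on an aromatic carbon. Going by the values given here, the one step at the same place, a 1.7-fold lower number from compound 1 to compound 2 (0.23 log units; within the scatter), was within the scatter, so this halogen exchange is expected to give no step beyond the scatter, a 1.2-fold lower number from compound 2 to compound 3 (0.08 log units; within the scatter). Compound 3 is therefore estimated at 5 ug/mL, with a range from 2.5 ug/mL to 12 ug/mL.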

Compound 3, half-maximal inhibitory concentration: 12.6 ug/mL
Estimate against measurement, compound 3: 2.5-fold (0.40 log units) below, outside the stated range (above it).
By their numbers in this assay, from the lowest: compounds 2, 1 and 3 (each within the scatter of the next, the first and the last beyond it).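

In this assay, for the compounds shown here, the change from 4-fluorophenyl to 4-bromophenyl gives the first step beyond the scatter at this position, a modest one: a 2.1-fold higher number from compound 2 to compound 3 (0.32 log units; beyond the scatter). Bromo and methyl are not separated here, a 1.2-fold higher number from compound 1 to compound 3 (0.09 log units; within the scatter), so the only separation at this position rests on fluoro in compound 2 against bromo in compound 3. No available evidence bears on this difference. From the compounds shown here alone, whether chloro, methoxy or an amine at this place would fall with fluoro or with bromo remains open.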